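Dimethoxy for dihydroxy on the diaryl ether series

A few compounds are considered here, and "the series" means these few. Any claim that something is new, unique, unknown or untested is made for them only; others in the source may bear on it.

Compound 1 `COc1ccc(Oc2ccc(C(C)C)cc2-c2ccsc2S(=O)(=O)NCCNC(=O)Nc2cc(Cl)cc(Cl)c2)cc1OC` carries a 3,4-dimethoxyphenoxy group; compound 2 `CC(C)c1ccc(Oc2ccc(O)c(O)c2)c(-c2ccsc2S(=O)(=O)NCCNC(=O)Nc2cc(Cl)cc(Cl)c2)c1` has the 3,4-dihydroxyphenoxy group on the same core, and compound 3 `CC(C)c1ccc(Oc2ccc(O)c(O)c2)c(-c2ccsc2S(=O)(=O)NCCNC(=O)Nc2cc(C(F)(F)F)cc(C(F)(F)F)c2)c1` keeps that dihydroxy group on a core that differs elsewhere. In a functional assay on RS4-11 cells (Homo sapiens) for inhibition, read by CCK-8 assay, with a stated time of 48 h (on this read-out lower numbers stand for stronger inhibition and higher numbers for weaker inhibition), compound 1 gives 9000 nM, compound 2 gives 6400 nM and compound 3 gives 6800 nM. The change from compound 2 to compound 1 is 3,4-dimethoxyphenyl in place of 3,4-dihydroxyphenyl on an oxygen on an aromatic ring, and it made a 1.4-fold higher number from compound 2 to compound 1 (0.15 log units; within the scatter). The difference between the core of compound 2 and the core of compound 3 is not broken down here; the two values of compound 2 and compound 3 lie close together. Compound 4 `COc1ccc(Oc2ccc(C(C)C)cc2-c2ccsc2S(=O)(=O)NCCNC(=O)Nc2cc(C(F)(F)F)cc(C(F)(F)F)c2)cc1OC` is not yet measured; it differs from compound 3 by 3,4-dimethoxyphenyl in place of 3,4-dihydroxyphenyl on an oxygen on an aromatic ring, which is the same change as that from compound 2 to compound 1, made at the same place. In this assay the step from compound 3 to compound 4 is expected to be a 1.4-fold higher number from compound 3 to compound 4 (0.15 log units; within the scatter), resting on a 1.4-fold higher number from compound 2 to compound 1 (0.15 log units; within the scatter) and on compound 3 at 6800 nM. Compound 4 is therefore estimated at 9500 nM, within 5000 nM to 18000 nM.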

Compound 4, half-maximal inhibitory concentration: 11700 nM
Estimate against measurement, compound 4: 1.2-fold (0.09 log units) below, and the stated range covers the measured number.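

On the second core, in this assay, 3,4-dimethoxyphenyl in place of 3,4-dihydroxyphenyl gives a 1.7-fold higher number from compound 3 to compound 4 (0.24 log units; within the scatter), and set beside the earlier step it does not differ: the same change on two cores in this assay, a 1.4-fold higher number (0.15 log units; within the scatter) from compound 2 to compound 1 and a 1.7-fold higher number (0.24 log units; within the scatter) from compound 3 to compound 4, 1.2-fold (0.09 log units) apart, within the scatter of two such steps

For these two cores, the change can therefore be carried from one to the other as a step that stays within the scatter. This does not show that the change has any real effect on the number in either core, and two cores are too few to say how it would behave across the wider series.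

The compounds shown leave open what an amine, a carboxylic acid or a longer chain such as 3,4-dipropoxyphenyl would give in place of the 3,4-dihydroxyphenyl group in this assay. Also open, as far as these compounds go, is whether the step would keep its size on a third core, and all four compounds leave the numbers in a narrow band that gives no guide to what would bring a clear gain.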